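The source may hold more compounds than are shown below. What is called first, only, known or untested is meant among the compounds shown, and "the series" means these compounds.

Working notes on the series.

Going by the values given here, compound 3, `CC(Sc1nc2c(cnn2C)c(=O)n1-c1ccc(CO)cc1)c1ccccc1`, in an assay on isolated protein for inhibition of aldehyde dehydrogenase 1A1 (Homo sapiens) (a higher number here means a weaker inhibitor, a lower number a stronger inhibitor), gives 600 nM, the highest of the three numbers so far. Compound 1, `CCC(Sc1nc2c(cnn2C)c(=O)n1-c1ccccc1)c1ccccc1`, gives 150 nM, and compound 2, `CC(Sc1nc2c(cnn2C)c(=O)n1-c1ccccc1)c1ccccc1`, gives 130 nM; the step of a 1.2-fold lower number from compound 1 to compound 2 (0.06 log units; within the scatter) shows that shortening the saturated chain next to the sulfur hardly registers, whereas the step of a 4.6-fold higher number from compound 2 to compound 3 (0.66 log units; beyond the scatter) shows that adding hydroxymethyl onto the aromatic carbon costs a modest amount.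

Compound 4, `CC(Sc1nc2c(cnn2C)c(=O)n1-c1ccc(CCO)cc1)c1ccccc1`, differs from compound 3 by hydroxymethyl in place of hydroxy on a saturated chain carbon bound to an aromatic carbon, that is, the hydroxymethyl of compound 3 grows into 2-hydroxyethyl. The one step that bears on this region, a 4.6-fold higher number from compound 2 to compound 3 (0.66 log units; beyond the scatter), concerns the appearance of the polar group, not its length; the only lengthening step shown, a 1.2-fold lower number from compound 1 to compound 2 (0.06 log units; within the scatter), lies within the scatter and sits elsewhere in the molecule. Nothing shown suggests a large move in either direction from compound 3 to compound 4, so a step of about a 1.1-fold higher number from compound 3 to compound 4 (0.03 log units; within the scatter) is expected, within the scatter. Compound 4 is therefore estimated at 650 nM, with a range from 250 nM to 1600 nM.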

Compound 4, half-maximal inhibitory concentration: 360 nM
For compound 4 the middle estimate is 1.8-fold (0.26 log units) above the measured one; low and high end bracket the measured number.
By their numbers in this assay, from the lowest: compounds 2 and 1 (each within the scatter of the next); then compounds 4 and 3 (each within the scatter of the next).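

Growing hydroxymethyl into 2-hydroxyethyl gives a 1.7-fold lower number from compound 3 to compound 4 (0.22 log units; within the scatter) in this assay, so the added chain carbon does not shift the number beyond the scatter. Measured against hydrogen on the aromatic carbon, 2-hydroxyethyl gives a 2.8-fold higher number from compound 2 to compound 4 (0.44 log units; beyond the scatter) and so still carries a modest loss, which means the loss seen with hydroxymethyl is not confined to that one chain length. No supporting data bear on why either step has this size.

On these data alone, whether a longer chain such as 3-hydroxypropyl, or an amine or a carboxylic acid in place of the hydroxy, would stay in the same range remains open. The compounds shown also do not separate the contribution of the chain carbons from that of the hydroxy, a question on which an ethyl group on the same aromatic carbon would bear.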